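A few compounds are considered here, and "the series" means these few. Any claim that something is new, unique, unknown or untested is made for them only; others in the source may bear on it.

Measured so far in a functional assay on the whole organism (Cricetulus griseus) with Cricetinae gen. sp. as the target; on this read-out higher numbers stand for an effect only at larger amounts of compound and lower numbers for an effect already at smaller amounts:
compound 1, `CCc1ccccc1-c1n[nH]c(-c2ccccc2)n1`, gives 0.15 mg/kg;
compound 2, `CC(C)c1ccccc1-c1n[nH]c(-c2ccccc2)n1`, gives 10 mg/kg;
compound 3, `CCCCc1ccccc1-c1n[nH]c(-c2ccccc2)n1`, gives 17 mg/kg.

Compound 1 has the lowest number of the three, so it acts at the smallest dose. Enlarging its ethyl chain costs a great deal: a 67-fold higher number from compound 1 to compound 2 (1.82 log units; beyond the scatter) and a 110-fold higher number from compound 1 to compound 3 (2.05 log units; beyond the scatter). Between the two larger chains the difference is small, a 1.7-fold higher number from compound 2 to compound 3 (0.23 log units; within the scatter), within the scatter.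

Compound 4, `CCc1ccccc1-c1n[nH]c(-c2cccc(-c3ccccc3)c2)n1`, differs from compound 1 at the other end of the shared core: phenyl in place of hydrogen on an aromatic carbon, meta to a large group. The chain that was so sensitive in the measured steps stays as in compound 1. Among the measured compounds shown here, none of the measured steps touches the ring that is changed here, so no step bears directly on this change, and the expectation must rest on compound 1 alone, with a wide range. A modest step is expected, a 3.3-fold higher number from compound 1 to compound 4 (0.52 log units; beyond the scatter). For compound 4 the estimate is 0.5 mg/kg, expected to fall between 0.1 mg/kg and 3 mg/kg.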

Compound 4, dose for half-maximal effect: 10 mg/kg
Estimate against measurement, compound 4: 20-fold (1.30 log units) below, outside the stated range (above it).
By their numbers in this assay, from the lowest: compound 1; then compounds 2, 4 and 3 (each within the scatter of the next).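

In this assay, the ring at the other end of the shared core proves as demanding as the ethyl chain: phenyl in place of hydrogen on an aromatic carbon, meta to a large group, gives a 67-fold higher number from compound 1 to compound 4 (1.82 log units; beyond the scatter) on this read-out. The low dose of compound 1 therefore does not rest on its ethyl chain alone, since a change that leaves this chain untouched also carries a large cost. Nothing available here explains the size of this step.

With a single example at this place, the compounds shown leave open whether any added group costs this much or whether the cost is particular to phenyl. A methyl, a fluorine, an amine or a carboxylic acid on this ring could answer that question.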